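Three Inactive Analogues and a Dimethylphenyl Replacement

A few compounds are considered here, and "the series" means these few. Any claim that something is new, unique, unknown or untested is made for them only; others in the source may bear on it.

Compound 3 `N#CC1=C(N)Oc2c(N)cc3nc4ccccc4nc3c2C12C(=O)N(Cc1cnnn1-c1cccc(Br)c1)c1ccccc12` belongs to a set of three compounds that share one core and differ only in the aryl group attached to the triazole nitrogen. In a functional assay on HepG2 cells (Homo sapiens) for antiproliferative activity, read by MTT assay, with a stated time of 48 h (on this read-out higher numbers stand for weaker inhibition and lower numbers for stronger inhibition), compound 3 gives > 50000 nM, which is a limit of the assay rather than a measured number. Compound 1 `N#CC1=C(N)Oc2c(c3nc4ccccc4nc3c3ccccc23)C12C(=O)N(Cc1cnnn1-c1ccccc1Br)c1ccccc12` in this assay gives > 50000 nM, likewise a limit. Compound 2 `N#CC1=C(N)Oc2c(c3nc4ccccc4nc3c3ccccc23)C12C(=O)N(Cc1cnnn1-c1ccc(Cl)c(Cl)c1)c1ccccc12` in this assay gives > 50000 nM, again a limit. Because all three sit at the limit of > 50000 nM in this assay, at which 3 of the 3 values shown sit, nothing within the set separates one compound from another, and the step that the two limits leave unreadable from compound 1 to compound 2 stays unreadable.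

Compound 4 `Cc1cc(C)cc(-n2nncc2CN2C(=O)C3(C(C#N)=C(N)Oc4c(N)cc5nc6ccccc6nc5c43)c3ccccc32)c1` is the next member. Its change from compound 3 is 3,5-dimethylphenyl in place of 3-bromophenyl on an aromatic nitrogen. For the measured compounds named here, no measured step gives a readable size for an aryl swap on this nitrogen, so the expectation rests only on where compound 3 stands. Since every measured compound sits at the limit, compound 4 is expected to do the same, with a step that the limit leaves unreadable from compound 3 to compound 4 that is an estimate rather than a shown value. The estimate for compound 4 in this assay is 60000 nM, with a range from 20000 nM to 200000 nM, and most likely the assay will again report only a limit.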

Compound 4, half-maximal inhibitory concentration: > 50000 nM
Compound 4: only a limit was reported; the forecaster's own chance of this, stated with the estimate: 80%; the middle value is on the limit's open side.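

Compound 4 in this assay gives > 50000 nM as a limit of the assay and not a number, so the change from compound 3 to compound 4 has no readable size. The compounds shown leave open whether any aryl group on this aromatic nitrogen, or any change in the shared core, gives a measurable value in this assay at all.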